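Compound 2 to compound 3: replacing the methylsulfonyl aryl group

The source may report more compounds than this note shows. Statements on the series, on what has been measured and on what is new or still open speak of the compounds shown alone.

Values in an ADME assay on BJ cells (Homo sapiens) for cytotoxicity, with a stated time of 72 h (a lower number here means that less compound is needed, a higher number that more compound is needed for the effect), follow.

- compound 1 `Cc1ccc(-c2nc3c(c(C)nn3-c3ccccc3)c(-c3ccccc3O)c2C#N)cc1` gives 22200 nM
- compound 2 `Cc1nn(-c2ccccc2)c2nc(-c3ccc(S(C)(=O)=O)cc3)c(C#N)c(-c3ccccc3O)c12` gives > 20000 nM as a limit

Compound 2 has no number on this scale, only a limit (the limit of > 20000 nM in this assay, at which 1 of the 2 values shown sits). Compound 3 `Cc1nn(-c2ccccc2)c2nc(-c3ccc4c(c3)CCCC4)c(C#N)c(-c3ccccc3O)c12` remains unmeasured, and its structure departs from that of compound 2 (1,2,3,4-tetrahydronaphthalen-6-yl in place of 4-(methylsulfonyl)phenyl on an aromatic carbon). In words, 1,2,3,4-tetrahydronaphthalen-6-yl stands in place of 4-(methylsulfonyl)phenyl on an aromatic carbon. Going by the values given here, the one measured step at this place (a step that the limit leaves unreadable from compound 1 to compound 2) has no readable size, so it fixes neither a size nor a direction. The expectation therefore leans on compound 1 (22200 nM), whose methyl-bearing group also lacks the methylsulfonyl group. The estimated step (an at least 1.1-fold lower number from compound 2 to compound 3 (0.04 log units; that floor lies within the scatter)) is expected to be small, with no firm direction. Compound 3 is estimated at 18000 nM (expected range 7000 nM to 45000 nM).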

Compound 3, half-maximal effective concentration in the BJ assay: > 20000 nM
Compound 3: a limit, no number; the forecaster's own chance of this, stated with the estimate: 45%; at least 1.1-fold (0.04 log units) between middle value and limit.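

In the BJ assay compound 3 gives > 20000 nM as a limit and not a number. Going by these compounds alone, in the BJ assay compound 2 gives > 20000 nM as a limit as well, so no step among compound 1, compound 2 and compound 3 can be read. The compounds shown leave open whether the group changed at this place shifts the value in the BJ assay at all. In a physicochemical assay for solubility, read by spectrophotometry, in phosphate buffer, with a stated time of 18 h, at pH 7.4 (on this read-out higher numbers stand for higher solubility and lower numbers for lower solubility), compound 2 gives 5000 nM and compound 3 gives 13000 nM with a 2.6-fold higher number from compound 2 to compound 3 (0.41 log units; beyond the scatter) on this read-out.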